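This account rests on a few compounds, and the source may have more. Where it says the series, first, only, none or still open, it means among the compounds named here.

Compound 2 `COc1cc2c(Oc3ccc(NC(=O)c4cn(-c5ccccc5)nn4)cc3F)ccnc2cc1OCCCN1CCCCC1` and compound 1 `COc1cc2c(Oc3ccc(NC(=O)c4cn(-c5ccccc5)nn4)cc3F)ccnc2cc1OCCCN1CCCC1` share one core and differ only in the saturated ring at the end of the chain. In a functional assay on NCI-H460 cells (Homo sapiens) for cytotoxicity, read by MTT assay, with a stated time of 72 h (on this read-out lower numbers stand for stronger inhibition and higher numbers for weaker inhibition), compound 2 gives 210 nM, and in this assay compound 1 gives 280 nM; the step of a 1.3-fold lower number from compound 1 to compound 2 (0.12 log units; within the scatter) lies within the usual scatter, so the two numbers cannot be told apart. Compound 3 `COc1cc2c(Oc3ccc(NC(=O)c4cn(-c5c(C)cccc5C)nn4)cc3F)ccnc2cc1OCCCN1CCCCC1` keeps the piperidin-1-yl chain of compound 2 and differs from it by 2,6-dimethylphenyl in place of phenyl on an aromatic nitrogen. For the measured compounds named here, no measured step touches this part of the molecule: the single step recorded concerns the saturated ring on the chain, not the group on the aromatic nitrogen. With nothing to show how the dimethyl substitution shifts the number, compound 3 is expected to give a number close to that of compound 2, with a wide margin; the expected step is a 1.2-fold higher number from compound 2 to compound 3 (0.08 log units; within the scatter). Compound 3 is therefore estimated at 250 nM, with a range from 80 nM to 800 nM.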

Compound 3, half-maximal inhibitory concentration: 3520 nM
Estimate against measurement, compound 3: 14-fold (1.15 log units) below, and the stated range ends below it.
By their numbers in this assay, from the lowest: compounds 2 and 1 (each within the scatter of the next); then compound 3.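

In this assay, the group on the aromatic nitrogen proves far more consequential than the saturated ring on the chain: replacing phenyl with 2,6-dimethylphenyl gives a 17-fold higher number from compound 2 to compound 3 (1.22 log units; beyond the scatter) and this lies beyond the scatter, whereas a 1.3-fold lower number from compound 1 to compound 2 (0.12 log units; within the scatter) stays within it. The leaving and entering groups are both carbon-only six-membered aromatic rings with no hydrogen-bond donors or acceptors and no net charge, yet this change alone separates compound 3 from compound 2. Nothing available here accounts for the size of this step.

The compounds shown leave open whether benzyl, cyclohexyl or a plain methyl on that nitrogen would keep the number of compound 2 or raise it. They also leave open whether 2,6-dimethylphenyl would have a similar effect alongside the pyrrolidin-1-yl chain of compound 1.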